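The compounds below may be only part of what the source reports. "The series", "measured", "known", "first", "only" and "open" are said of these compounds alone.

Measured in a functional assay on MDA-MB-231 cells (Homo sapiens) for antiproliferative activity, with a stated time of 4 days (a higher number here means a weaker inhibitor, a lower number a stronger inhibitor), are two compounds
Compound 1 `COc1ccc(-c2[nH]c3ccc(F)cc3c2C=C(C#N)C#N)cc1` gives 400 nM
Compound 2 `CCCc1ccc2[nH]c(-c3ccc(OC)cc3)c(C=C(C#N)C#N)c2c1` gives 83 nM

Among the compounds with values here, compound 2 holds the lower of these two numbers, and compound 1 is its only neighbour. Going to compound 3 `CCCCCCc1ccc2[nH]c(-c3ccc(OC)cc3)c(C=C(C#N)C#N)c2c1` means propyl in place of hydrogen on a saturated chain carbon, three bonds along the chain from an aromatic carbon and the chain reads propyl to hexyl. Within the data shown here, the only measured step bearing on this is a 4.8-fold lower number from compound 1 to compound 2 (0.68 log units; beyond the scatter) and it is modest, with propyl in place of fluoro on an aromatic carbon. Among the measured compounds shown here, that is a different change, and no measured compound carries a longer chain, so no step beyond the scatter is expected in this assay here. Going by these compounds, the estimated step is a 1.2-fold higher number from compound 2 to compound 3 (0.08 log units; within the scatter) and its direction remains open. Compound 3 is expected at 100 nM with 30 nM to 350 nM as its estimated range.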

Compound 3, half-maximal inhibitory concentration: 46 nM
Estimate against measurement, compound 3: 2.2-fold (0.34 log units) above; the range from low to high includes it.
By their numbers in this assay, from the lowest: compounds 3 and 2 (each within the scatter of the next); then compound 1.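

In this assay, within the data shown here, the chain reading propyl to hexyl gives a 1.8-fold lower number from compound 2 to compound 3 (0.26 log units; within the scatter), so this change on a saturated chain carbon leaves compound 2 and compound 3 within the scatter of each other, which the earlier compounds could not show. Swapping the fluoro group for the hexyl chain gives an 8.7-fold lower number from compound 1 to compound 3 (0.94 log units; beyond the scatter), so compound 2 and compound 3 both stand beyond the scatter of compound 1. Nothing measured here accounts for these numbers. Going by these compounds, whether a longer chain or an amine in place of hexyl would stay within the scatter of compound 3 remains open.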